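Aryl swap at the benzylic amine of a bis(trifluoromethyl) sulfonamide

This account rests on a few compounds, and the source may have more. Where it says the series, first, only, none or still open, it means among the compounds named here.

Measured compounds:
compound 1, `O=S(=O)(NCCCNCc1ccccc1Cl)c1cc(C(F)(F)F)cc(C(F)(F)F)c1`, 11000 nM
compound 2, `O=S(=O)(NCCCNCc1ccc(Br)cc1)c1cc(C(F)(F)F)cc(C(F)(F)F)c1`, 1500 nM

Compound 2 gives the lowest of the two numbers in a functional assay on BXPC-3 cells (Homo sapiens) for inhibition, read by MTT assay, with a stated time of 72 h; on this read-out higher numbers stand for weaker inhibition of growth and lower numbers for stronger inhibition of growth; the step of a 7.3-fold lower number from compound 1 to compound 2 (0.87 log units; beyond the scatter) shows that exchanging the aryl group on the saturated chain carbon bound to the amine nitrogen moves this read-out well beyond the scatter. Compound 3, `O=S(=O)(NCCCNCc1cccc2ccccc12)c1cc(C(F)(F)F)cc(C(F)(F)F)c1`, continues at that same place with naphthalen-1-yl in place of 4-bromophenyl on a saturated chain carbon bound to an amine nitrogen. Among the compounds with values here, the only step that bears on it is the one from compound 1 to compound 2, an aryl exchange of modest size, but the pair gives no direction for a two-ring system. Since compound 2 already holds the lower of the two numbers, the account expects compound 3 to stay near it, with a step of no change at the digits printed from compound 2 to compound 3 (within the scatter) that is not expected to exceed the scatter. The estimate for compound 3 is therefore 1500 nM, with a range from 500 nM to 5000 nM.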

Compound 3, concentration for 50% growth inhibition: 2700 nM
Estimate against measurement, compound 3: 1.8-fold (0.26 log units) below; the range from low to high includes it.
By their numbers in this assay, from the lowest: compounds 2 and 3 (each within the scatter of the next); then compound 1.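

In this assay, the place on a saturated chain carbon bound to an amine nitrogen also tolerates naphthalen-1-yl, with its 2 six-membered aromatic rings: with a 1.8-fold higher number from compound 2 to compound 3 (0.26 log units; within the scatter), this group and 4-bromophenyl cannot be told apart. Against 2-chlorophenyl the same group stands clear, with a 4.1-fold lower number from compound 1 to compound 3 (0.61 log units; beyond the scatter), so compound 1 alone lies apart among the three, and bromine is not required to reach the level of compound 2. Nothing measured here explains why these aryl groups fall as they do.

On these data alone, whether the weaker result of compound 1 belongs to the chlorine itself or to where it sits stays open, and a 4-chlorophenyl group would bear on that question. Also open, as far as these compounds go, is how naphthalen-2-yl, or a longer chain in the shared core, would read.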